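The compounds below may be only part of what the source reports. "The series", "measured", "known", "first", "only" and "open" are said of these compounds alone.

Compound 1 `CC(C)c1cccc(C(C)C)c1NC(=O)CC(=O)OC(c1ccccn1)c1ccccn1` in an assay on microsomes from intestine for inhibition of acyl-CoA:cholesterol acyltransferase (Oryctolagus cuniculus) (a higher number here means a weaker inhibitor, a lower number a stronger inhibitor), gives > 5000 nM, a limit of the assay.
Compound 2 `CC(C)c1cccc(C(C)C)c1NC(=O)CC(=O)O` in this assay gives > 5000 nM, again a limit rather than a number.
Compound 3 `CCCCCCCCCCCCC(C)(C)OC(=O)CC(=O)Nc1c(C(C)C)cccc1C(C)C` in this assay gives 12 nM.

Compound 2 thus sits at the limit of > 5000 nM in this assay, at which 2 of the 3 values shown sit, a place it shares with compound 1, so nothing separates those two; only compound 3 returns a number. Compound 4 `CCCCCCOC(=O)CC(=O)Nc1c(C(C)C)cccc1C(C)C` is next to be measured in this assay. It differs from compound 2 by hexyl in place of hydrogen on an oxygen next to a carbonyl group. Where compound 2 has the free acid, an ester is carried by compound 3, which gives 12 nM. On that basis the step is expected to be large and toward stronger inhibition, an at least 25-fold lower number from compound 2 to compound 4 (1.39 log units; beyond the scatter). Compound 4 is estimated to come in near 200 nM, within 40 nM to 1500 nM.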

Compound 4, half-maximal inhibitory concentration: 810 nM
Estimate against measurement, compound 4: 4.1-fold (0.61 log units) below, and the stated range covers the measured number.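

In this assay, going by these compounds alone, hexyl in place of hydrogen on this oxygen gives an at least 6.1-fold lower number from compound 2 to compound 4 (0.79 log units; beyond the scatter), the first step that can be read. The step has only a lower bound, since compound 2 stands at a limit: the limit of > 5000 nM in this assay, at which 2 of the 4 values shown sit. An ester here does not fix the value by itself: compound 4 gives 810 nM and compound 3 gives 12 nM.

Still open, on these data alone, is whether chain length or the branching of the ester chain sets that gap. Also open, as far as these compounds go, is whether an unbranched dodecyl chain or an amide in place of the ester would keep the value.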